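Swapping Trifluoromethyl for Methyl on an Aromatic Ring

The source may hold more compounds than are shown below. What is called first, only, known or untested is meant among the compounds shown, and "the series" means these compounds.

Measured so far:
- compound 1, `Cc1ccc(N2CC(c3nc(-c4cccc(C(F)(F)F)c4)no3)CC2=O)cc1`: 3400 nM
- compound 2, `O=C1CC(c2nc(-c3ccc(Cl)cc3)no2)CN1c1ccc(Cl)c(Cl)c1`: 1100 nM
- compound 3, `Cc1cccc(N2CC(c3nc(-c4cccc(Cl)c4)no3)CC2=O)c1`: a limit of the assay, > 10000 nM

In an in vitro functional assay on HEK293-A cells for positive allosteric modulation of metabotropic glutamate receptor 5 (Homo sapiens), read by FLIPR and calcium flux (a higher number here means that more compound is needed for the effect, a lower number that less compound is needed), compound 1 gives 3400 nM, the highest of the two numbers. Compound 2 gives 1100 nM, a lower number, and the gap between compound 1 and compound 2 lies beyond the usual scatter. Compound 3 reaches only the limit (the limit of > 10000 nM in this assay, at which 1 of the 3 values shown sits), so no number is known for it.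

Compound 4, `Cc1ccc(N2CC(c3nc(-c4cccc(C)c4)no3)CC2=O)cc1`, shares the core of compound 1 and differs in one place: methyl in place of trifluoromethyl on an aromatic carbon. Among the compounds with values here, no measured pair shows this change on its own, so its size is not known from the data. Compound 3, which carries a chlorine on that ring instead, reaches only a limit, and a modest loss is expected when the trifluoromethyl group gives way to the smaller methyl group, though a change within the scatter cannot be ruled out. The step from compound 1 to compound 4 is therefore estimated at a 1.8-fold higher number from compound 1 to compound 4 (0.25 log units; within the scatter). Compound 4 is expected to give about 6000 nM, within a range from 2000 nM to 20000 nM.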

Compound 4, half-maximal effective concentration: 1300 nM
Compound 4: middle estimate off by 4.6-fold (0.66 log units), on the high side; the whole stated range lies above it.
By their numbers in this assay, from the lowest: compounds 2 and 4 (each within the scatter of the next); then compound 1. At a limit, above all of these: compound 3.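

In this assay, the trifluoromethyl group is not needed at this position on the aromatic ring: methyl in its place gives a 2.6-fold lower number from compound 1 to compound 4 (0.42 log units; beyond the scatter). The change removes three fluorine atoms and leaves one heavy atom where there were four, yet less compound is needed for the effect, and the step lies beyond the usual scatter. Nothing measured here gives a reason for this step.

This single pair cannot tell whether the same swap would give a step of similar size or direction on other compounds, with different groups elsewhere on the shared core. Also open, as far as these compounds go, is how this position would respond to an ethyl group, a methoxy group, a nitrile or an amine, or to plain hydrogen with no group at all.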